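The compounds below may be only part of what the source reports. "The series", "measured", "known", "first", "only" and "open" are said of these compounds alone.

Measured compounds: compound 1 `CCOC(=O)C(=O)CC(=O)/C=C/c1cn(Cc2ccc(C#N)cc2)c2ccccc12` gives > 40 uM in an assay on isolated protein for inhibition of DNA nucleotidylexotransferase (Homo sapiens), read by scintillation counting, with a stated time of 10 min (on this read-out higher numbers stand for weaker inhibition and lower numbers for stronger inhibition), which is a limit of the assay and not a number. Compound 2 `C=C(C)Cn1cc(/C=C/C(=O)CC(=O)C(=O)O)c2ccccc21` gives 2.5 uM. Compound 3 `O=C(/C=C/c1cn(Cc2ccccc2)c2ccccc12)CC(=O)C(=O)O` gives 7.9 uM.

Among the two numbers shown in this assay, compound 3 stands highest; its nearest neighbour is compound 2, and the step of a 3.2-fold higher number from compound 2 to compound 3 (0.50 log units; beyond the scatter) is beyond the scatter. Compound 4 `N#Cc1ccc(Cn2cc(/C=C/C(=O)CC(=O)C(=O)O)c3ccccc32)cc1` differs from compound 3 by cyano in place of hydrogen on an aromatic carbon. Among the measured compounds shown here, no measured step bears directly on this change; the only measured step concerns the other end of the benzyl group. Compound 1 carries the same cyanobenzyl group with an ester and sits at a limit. Compound 4 is therefore expected to give about 15 uM, between 4 uM and 60 uM, an expected step of a 1.9-fold higher number from compound 3 to compound 4 (0.28 log units; within the scatter).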

Compound 4, concentration for 50% inhibition: 1.4 uM
Beside the measured number, compound 4's estimate is 11-fold (1.03 log units) above it; the measured number lies below the stated range.
By their numbers in this assay, from the lowest: compounds 4 and 2 (each within the scatter of the next); then compound 3. At a limit, above all of these: compound 1.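

In this assay, among the compounds shown here, benzyl to 4-cyanobenzyl gives a 5.6-fold lower number from compound 3 to compound 4 (0.75 log units; beyond the scatter), the first measured change on that aromatic ring, and 4-cyanophenyl in place of 1-methylethenyl gives a 1.8-fold lower number from compound 2 to compound 4 (0.25 log units; within the scatter), so the phenyl step from the earlier pair no longer separates the two. With the 4-cyanobenzyl group held constant, hydrogen in place of ethyl gives an at least 28-fold lower number from compound 1 to compound 4 (1.45 log units; beyond the scatter). The value of compound 1 is a limit of the assay, not a number: the limit of > 40 uM in this assay, at which 1 of the 4 values shown sits.

The compounds shown leave open whether an amine or a methoxy group on the same aromatic carbon would match cyano, and whether cyano elsewhere on that ring would do the same.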